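The source may hold more compounds than are shown below. What is called first, only, known or untested is meant among the compounds shown, and "the series" means these compounds.

Working notes on the series, read in a functional assay on Kasumi 1 cells (Homo sapiens) for cytotoxicity, read by resazurin assay, with a stated time of 72 h; a higher number here means a weaker inhibitor, a lower number a stronger inhibitor. Among the measured compounds shown here, compound 1 `C=CC(=O)Nc1cccc(Sc2c(OC)nc(N3CCN(C)CC3)nc2OC)c1` gives 7800 nM, the lowest of the three numbers measured so far. Compound 3 `Cc1nc(N2CCN(C)CC2)nc(C)c1Sc1nccc(NC(=O)c2ccco2)n1` gives 30300 nM and compound 2 `CCOc1nc(N2CCN(C)CC2)nc(OCC)c1Sc1nc(N)cc(NC(=O)CC)n1` gives 51400 nM, both higher than compound 1 by more than the scatter. For the measured compounds named here, no two of these three differ in one place only, so no measured step bears directly on the next change.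

Compound 4 `COc1nc(N2CCN(C)CC2)nc(OC)c1Sc1cccc(NC(=O)CN)c1` keeps the core of compound 1 and has aminomethyl in place of vinyl on a carbonyl carbon. Going by the values given here, compound 1 is the only measured member carrying vinyl. The two without it, compound 3 at 30300 nM and compound 2 at 51400 nM, both read higher, although they also differ from compound 1 elsewhere. A moderate rise beyond the scatter, towards a weaker inhibitor, is expected, with an estimated step of a 2.6-fold higher number from compound 1 to compound 4 (0.41 log units; beyond the scatter). For compound 4 the estimated value is 20000 nM, with an expected range of 7000 nM to 55000 nM.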

Compound 4, half-maximal inhibitory concentration: 22500 nM
Beside the measured number, compound 4's estimate is 1.1-fold (0.05 log units) below it, within the range that was stated.
By their numbers in this assay, from the lowest: compound 1; then compounds 4, 3 and 2 (each within the scatter of the next, the first and the last beyond it).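

With the core of compound 1 held, aminomethyl in place of vinyl on a carbonyl carbon gives, in this assay, a 2.9-fold higher number from compound 1 to compound 4 (0.46 log units; beyond the scatter), a modest step. Among the compounds shown here, compounds 2 and 3 also differ from compound 1 elsewhere, so this is the first reading that ties a change in the number to this position alone. No measurement bearing on the reason for the step is available.

This single step swaps vinyl and its double bond for aminomethyl, so it leaves open whether the rise follows from the loss of vinyl or from the entry of the amine. From the compounds shown here alone, a plain methyl or a longer chain such as aminoethyl on the same carbonyl carbon would help to separate the two, and whether the step carries over to other cores also remains open.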